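The compounds below may be only part of what the source reports. "The series", "measured", "known", "first", "only" and "open" are said of these compounds alone.

Measured in an ADME assay (liver) for metabolic stability, with Liver microsome (Homo sapiens) as the target, using microsomes and NADPH, with a stated time of 30 min, tested at 1 uM; on this read-out higher numbers stand for fast clearance and lower numbers for slow clearance:
Compound 1 `Nc1ccc(S(=O)(=O)N2CCN(c3ncc(C(O)(C(F)(F)F)C(F)(F)F)cc3-c3ccncc3)CC2)cn1`: 15 mL.min-1.g-1
Compound 2 `Nc1ccc(S(=O)(=O)N2CCN(c3ncc(C(O)(C(F)(F)F)C(F)(F)F)cc3-c3cncc(F)c3)CC2)cn1`: 24 mL.min-1.g-1
Compound 3 `Nc1ccc(S(=O)(=O)N2CCN(c3ncc(C(O)(C(F)(F)F)C(F)(F)F)cc3-c3ccc4scnc4c3)CC2)cn1`: 39 mL.min-1.g-1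

Compound 3 stands at 39 mL.min-1.g-1. Its gap to one neighbour exceeds the usual scatter, as shown by the measured step of a 2.6-fold higher number from compound 1 to compound 3 (0.41 log units; beyond the scatter). Its gap to the other does not, as shown by a 1.6-fold higher number from compound 2 to compound 3 (0.21 log units; within the scatter).

The change now in question leads to compound 4 `Nc1ccc(S(=O)(=O)N2CCN(c3ncc(C(O)(C(F)(F)F)C(F)(F)F)cc3-c3ccc4ocnc4c3)CC2)cn1`, with 1,3-benzoxazol-5-yl in place of 1,3-benzothiazol-5-yl on an aromatic carbon, ortho to a large group: 1,3-benzoxazol-5-yl in place of 1,3-benzothiazol-5-yl on an aromatic carbon.

Among the measured compounds shown here, no measured step makes this exact exchange, so the evidence is indirect. The three compounds differ only in the group at this place, and the steps among them remain small. The largest, a 2.6-fold higher number from compound 1 to compound 3 (0.41 log units; beyond the scatter), is modest, and a 1.6-fold higher number from compound 1 to compound 2 (0.20 log units; within the scatter) lies within the scatter. Both of those steps replace pyridin-4-yl, whereas the new exchange keeps the ring count of the departing group and alters one hetero atom. No shift beyond the scatter is therefore expected in this assay, and the direction cannot be told with confidence from these data.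

The expected change is a 1.2-fold lower number from compound 3 to compound 4 (0.09 log units; within the scatter).

Compound 4 is estimated at 32 mL.min-1.g-1, with an expected range from 16 mL.min-1.g-1 to 60 mL.min-1.g-1.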

Compound 4, intrinsic clearance in microsomes: < 14 mL.min-1.g-1
Compound 4 gave a limit, no number; the forecaster's own chance of this, stated with the estimate: 2%; middle value at least 2.2-fold (0.35 log units) from the limit.
By their numbers in this assay, from the lowest: compounds 1, 2 and 3 (each within the scatter of the next, the first and the last beyond it). At a limit, below all of these: compound 4.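

In this assay, compound 4 gave a limit and not a number: the limit of < 14 mL.min-1.g-1 in this assay, at which 1 of the 4 values shown sits.

Among the compounds shown here, at this place, on an aromatic carbon ortho to a large group, 1,3-benzoxazol-5-yl in place of 1,3-benzothiazol-5-yl keeps the count of heavy atoms and the ring types and exchanges only sulfur for oxygen, yet it gives an at least 2.7-fold lower number from compound 3 to compound 4 (0.44 log units; beyond the scatter), so the read-out at this position responds to a single hetero atom, which the earlier compounds, differing by whole groups of other ring types, did not show. The other two steps set only floors that lie within the scatter, an at least 1.7-fold lower number from compound 2 to compound 4 (0.23 log units; that floor lies within the scatter) and an at least 1.0-fold lower number from compound 1 to compound 4 (0.02 log units; that floor lies within the scatter), so compound 4 cannot be ordered against compound 1 or compound 2.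

On these data alone, how far compound 4 lies under its limit stays open, and so does the true size of all three steps. Also open, as far as these compounds go, is how a 1,3-benzoxazol-5-yl carrying a methyl group or an amine would read at this place, and whether the exchange of sulfur for oxygen would have the same result with another group elsewhere on the shared core.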